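The compounds below may be only part of what the source reports. "The series", "measured", "known", "first", "only" and "open" are said of these compounds alone.

Compound 1 `NC(=S)N/N=C/c1cc2cccnc2s1` gives 6290 nM in a functional assay on HeLa cells (Homo sapiens) for antiproliferative activity, read by sulforhodamine B assay, with a stated time of 72 h; on this read-out higher numbers stand for weaker inhibition and lower numbers for stronger inhibition. Compound 2 `Cc1ccc(NC(=S)N/N=C/c2ccc3ccccc3n2)cc1` gives 86000 nM in this assay, the higher of the two numbers recorded there; its nearest neighbour is compound 1, whose number is clearly lower, a gap beyond the usual scatter. Compound 3 `Cc1ccc(NC(=O)N/N=C/c2ccc3ccccc3n2)cc1` reaches only a limit of this assay, > 100000 nM, and no number. Compound 4 `S=C(N/N=C/c1ccc2ccccc2n1)Nc1ccccc1` has not yet been measured. It differs from compound 2 in one place: hydrogen in place of methyl on an aromatic carbon. The methyl leaves, a hydrogen enters on the aromatic carbon, and the 4-methylphenyl becomes a phenyl. Among the measured compounds shown here, no measured pair shows this change, so in this assay a step of no more than the scatter is expected, if anything toward a slightly higher number. Compound 4 is therefore expected to give about 100000 nM, within 35000 nM to 300000 nM. The expected step of a 1.2-fold higher number from compound 2 to compound 4 (0.07 log units; within the scatter) stays within the scatter, and because compound 2 already sits close to the limit of > 100000 nM in this assay, at which 1 of the 3 values shown sits, a limit rather than a number remains a real possibility.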

Compound 4, half-maximal inhibitory concentration: 27400 nM
Compound 4: the middle estimate sits 3.6-fold (0.56 log units) above what was measured; the whole stated range lies above it.
By their numbers in this assay, from the lowest: compound 1; then compound 4; then compound 2. At a limit, above all of these: compound 3.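

Among the compounds shown here, replacing the methyl with hydrogen on the aromatic carbon para to a large group gives a 3.1-fold lower number from compound 2 to compound 4 (0.50 log units; beyond the scatter) in this assay, and this is the first measured pair to test this position. It shows that the position is not silent: the modest step goes toward stronger inhibition, so the 4-methylphenyl carries the weaker number and the phenyl the stronger one. Compound 3 still stands at a limit and has no number: the limit of > 100000 nM in this assay, at which 1 of the 4 values shown sits.

As far as these compounds go, what an amine, a methoxy group or a chlorine on this same carbon would give remains open, since only methyl and hydrogen are compared here. A single pair also cannot tell whether the same change would carry over to compound 3, with its carbonyl, or to other cores such as that of compound 1.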